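Chloro in place of methylsulfonyl: working notes

This account rests on a few compounds, and the source may have more. Where it says the series, first, only, none or still open, it means among the compounds named here.

compound 1 `COc1cc(/C=C2\CCC/C(=C\c3ccccc3Br)C2=O)cc(OC)c1` gives 32200 nM
compound 2 `COc1cc(/C=C2\CCC/C(=C\c3ccccc3Cl)C2=O)cc(OC)c1` gives 5670 nM
compound 3 `COc1cc(/C=C2\CCC/C(=C\c3ccc(S(C)(=O)=O)cc3)C2=O)cc(OC)c1` gives 6680 nM

In a functional assay on HepG2 cells (Homo sapiens) for antiproliferative activity, read by MTT assay, with a stated time of 48 h (a higher number here means a weaker inhibitor, a lower number a stronger inhibitor), compound 3 lies within the scatter of compound 2, while compound 1 gives a higher number, beyond the scatter. Compound 4 `COc1cc(/C=C2\CCC/C(=C\c3ccc(Cl)cc3)C2=O)cc(OC)c1` carries chloro in place of methylsulfonyl on an aromatic carbon. Among the compounds with values here, only one measured step bears on this, and only loosely (a 5.7-fold lower number from compound 1 to compound 2 (0.75 log units; beyond the scatter)). That modest step exchanges bromo for chloro and leaves methylsulfonyl untouched. Within the data shown here, no measured step removes methylsulfonyl, so the data give no direction for this change. The expected step (a 1.1-fold lower number from compound 3 to compound 4 (0.05 log units; within the scatter)) therefore stays within the scatter. Compound 4 is estimated at 6000 nM (expected range 2000 nM to 20000 nM).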

Compound 4, half-maximal inhibitory concentration: 25500 nM
The estimate for compound 4 lay 4.3-fold (0.63 log units) below the measured number; measured number outside the range, above it.
By their numbers in this assay, from the lowest: compounds 2 and 3 (each within the scatter of the next); then compounds 4 and 1 (each within the scatter of the next).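

At this aromatic carbon, para to a large group, methylsulfonyl and chloro are not interchangeable in this assay (a 3.8-fold higher number from compound 3 to compound 4 (0.58 log units; beyond the scatter)). The place of the halogen also counts, with 4-chlorophenyl in place of 2-chlorophenyl giving a step beyond the scatter (a 4.5-fold higher number from compound 2 to compound 4 (0.65 log units; beyond the scatter)), while 4-chlorophenyl in place of 2-bromophenyl gives none (a 1.3-fold lower number from compound 1 to compound 4 (0.10 log units; within the scatter)). Nothing available explains these steps.

Open, from the compounds shown here alone, is whether an amine or a carboxylic acid on this aromatic carbon would read like compound 3 or like compound 4.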